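Aldosterone synthase series: ring-constrained amide on the pyridine

The source may report more compounds than this note shows. Statements on the series, on what has been measured and on what is new or still open speak of the compounds shown alone.

Measured so far:
compound 1 `Cc1ccncc1C(=O)N1CC(Oc2cncc(N3C(=O)c4ccc(Cl)cc4C3(C)C)c2)C1` 4 nM
compound 2 `CCC(=O)NCc1cncc(N2C(=O)c3ccc(Cl)cc3C2(C)C)c1` 282 nM
compound 3 `CC(=O)N[C@@H]1CCCc2c1cncc2N1C(=O)c2ccc(Cl)cc2[C@@H]1C` 4 nM

In an assay on cells for inhibition of cytochrome P450 11B2, mitochondrial (Homo sapiens), read by HTRF (on this read-out higher numbers stand for weaker inhibition and lower numbers for stronger inhibition), compound 2 gives 282 nM, the highest of the three numbers; compounds 1 and 3 lie well beyond the scatter below it. Compound 4 `CC(=O)N1CCC(c2cncc(N3C(=O)c4ccc(Cl)cc4C3(C)C)c2)CC1` is not yet measured. Relative to compound 2 the change is 1-acetylpiperidin-4-yl in place of (propanoylamino)methyl on an aromatic carbon. Compound 1 reaches 4 nM and compound 3 reaches 4 nM, both carrying their amide within or on a ring system, whereas compound 2, with its open chain, sits far higher. Carrying the amide on a ring in compound 4 is therefore expected to move the number downward, by a step beyond the scatter, estimated as an 8.1-fold lower number from compound 2 to compound 4 (0.91 log units; beyond the scatter). For compound 4 the value is expected at about 35 nM, within 8 nM to 150 nM.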

Compound 4, half-maximal inhibitory concentration: 5 nM
For compound 4 the middle estimate is 7.0-fold (0.85 log units) above the measured one; measured number below the stated range.
By their numbers in this assay, from the lowest: compounds 1, 3 and 4 (each within the scatter of the next); then compound 2.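

In this assay, 1-acetylpiperidin-4-yl in place of (propanoylamino)methyl gives a 56-fold lower number from compound 2 to compound 4 (1.75 log units; beyond the scatter), so this aromatic carbon, two atoms from the ring nitrogen, tolerates the larger group with its six-membered non-aromatic ring. The same step also removes the hydrogen-bond donor, and this single pair cannot separate that loss from the entry of the ring. Nothing available explains the size of the step.

Still open, as far as these compounds go, is whether an open chain without the amide hydrogen would match compound 4. Also open, from the compounds shown here alone, is how a free piperidine amine or a carboxylic acid would fare at this carbon.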